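Series notes: tail changes on the shared core

The source may hold more compounds than are shown below. What is called first, only, known or untested is meant among the compounds shown, and "the series" means these compounds.

Three compounds of the series carry a measurement in a functional assay on MCF7 cells (Homo sapiens) for cytotoxicity, read by MTT assay, with a stated time of 24 h, tested at 6.4 ug/mL; a higher number here means a stronger effect of the compound at the concentration tested, a lower number a weaker effect. Compound 1 `Cn1c(-c2ccc(NC(=O)CCl)cc2)nc(-c2ccccc2)c1-c1ccccc1` gives 14.2% in this assay. Compound 2 `Cn1cnnc1SCC(=O)Nc1ccc(-c2nc(-c3ccccc3)c(-c3ccccc3)n2C)cc1` gives 59.2%, and compound 3 `Cc1nnc(SCC(=O)Nc2ccc(-c3nc(-c4ccccc4)c(-c4ccccc4)n3C)cc2)s1` gives 67.8%. Compound 3 thus holds the highest of the three numbers, though its gap to compound 2 is within the scatter, so neither of the two can be called the more active; only the gap to compound 1 is beyond the scatter. The measured steps are a number 45 percentage points higher from compound 1 to compound 2 (beyond the scatter) and a number 53.6 percentage points higher from compound 1 to compound 3 (beyond the scatter), both large, while a number 8.6 percentage points higher from compound 2 to compound 3 (within the scatter) stays within the scatter.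

Compound 4 `CCN1CCN(CC(=O)Nc2ccc(-c3nc(-c4ccccc4)c(-c4ccccc4)n3C)cc2)CC1` is not yet measured. Relative to compound 3 the change is 4-ethylpiperazin-1-yl in place of (5-methyl-1,3,4-thiadiazol-2-yl)sulfanyl on a saturated chain carbon bound to a carbonyl carbon. Going by the values given here, no measured step covers this kind of exchange: the two large steps replaced chloro with a heteroaryl sulfanyl group, and the small step swapped one five-membered ring for another on the sulfur. Going by these compounds, the departure from a sulfur-linked aromatic ring to a saturated ring is untested, so the expectation is uncertain. Compound 4 is estimated at 45%, with a range from 15% to 75%. This estimate means an expected step of a number 22.8 percentage points lower from compound 3 to compound 4 (beyond the scatter).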

Compound 4, a percentage reported as activity, at one concentration (the size of the read-out at that concentration, not a potency): 16.4%
Estimate against measurement, compound 4: 28.6 percentage points above; low and high end bracket the measured number.
By their numbers in this assay, from the lowest: compounds 1 and 4 (each within the scatter of the next); then compounds 2 and 3 (each within the scatter of the next).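

At the saturated chain carbon bound to a carbonyl carbon, this assay shows a number 51.4 percentage points lower from compound 3 to compound 4 (beyond the scatter) and a number 42.8 percentage points lower from compound 2 to compound 4 (beyond the scatter) when 4-ethylpiperazin-1-yl enters, both large, so the earlier rise over chloro does not extend to this saturated ring. With a number 2.2 percentage points higher from compound 1 to compound 4 (within the scatter) lying within the scatter, 4-ethylpiperazin-1-yl and chloro cannot be told apart here, and the tail changes so far fall into two levels: compounds 1 and 4 at the lower, compounds 2 and 3 at the higher. Nothing available bears on the reason for this separation.

The exchange in compound 4 removes the sulfur link and the five-membered aromatic ring together, so the contribution of each stays unresolved. A piperidin-4-ylsulfanyl group would keep the sulfur with a saturated ring, while a 1,2,4-triazol-1-yl group would keep an aromatic ring without the sulfur, and the two would separate these features at the same chain carbon.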